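The source may hold more compounds than are shown below. What is called first, only, known or untested is meant among the compounds shown, and "the series" means these compounds.

Compound 1 `CCCSc1nnc(COc2ccc(Cl)cc2Cl)o1` gives 13800 nM in a functional assay on BHK-21 cells (Mesocricetus auratus) for cytotoxicity, with a stated time of 5 days; on this read-out higher numbers stand for lower toxicity in this test and lower numbers for higher toxicity in this test. Compound 2 `ClCCCSc1nnc(Cc2ccc(Cl)cc2Cl)o1` is measured in this assay only as a limit, > 50000 nM, not as a number. Where compound 2 stands is therefore told only by the limit of > 50000 nM in this assay, at which 1 of the 2 values shown sits, so no exact distance between compound 2 and compound 1 can be read from the two values. Compound 3 `CCCSc1nnc(Cc2ccc(Cl)cc2Cl)o1` differs from compound 2 by hydrogen in place of chloro on a saturated chain carbon, three bonds along the chain from a sulfur, a change in a short side chain while the shared core and the dichlorinated aryl group remain. Because compound 2 sits at the limit of > 50000 nM in this assay, at which 1 of the 2 values shown sits, the step to compound 3 can be expected to stay small, within the usual scatter or only slightly toward higher toxicity, as given by an at least 1.2-fold lower number from compound 2 to compound 3 (0.09 log units; that floor lies within the scatter). Compound 3 is therefore estimated at 40000 nM in this assay, with a range from 15000 nM to 100000 nM.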

Compound 3, half-maximal cytotoxic concentration: > 50000 nM
Compound 3 ended at the assay's limit; the forecaster's own chance of this, stated with the estimate: 50%; middle value at least 1.2-fold (0.09 log units) away from the limit.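

Among these compounds, compound 2 and compound 3 both stand only as limits in this assay, so no step between them can be read: the limit of > 50000 nM in this assay, at which 2 of the 3 values shown sit. The compounds shown leave open whether going from 3-chloropropyl to propyl changes the toxicity in this test at all.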